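The source may hold more compounds than are shown below. What is called first, only, known or untested is meant among the compounds shown, and "the series" means these compounds.

Measured in an ADME assay on Vero cells (Chlorocebus sabaeus) for cytotoxicity, read by reporter gene assay, with a stated time of 4 days; on this read-out lower numbers stand for stronger inhibition and higher numbers for weaker inhibition:
compound 1 `CCCC(C)C(=O)NCC(C)(C)CC1=C(O)C(=O)c2ccccc2C1=O`: 48100 nM
compound 2 `CCCCCCC(=O)NCC(C)(C)CC1=C(O)C(=O)c2ccccc2C1=O`: 24800 nM
compound 3 `CCCCCCCCC(=O)NCC(C)(C)CC1=C(O)C(=O)c2ccccc2C1=O`: 16700 nM

Compound 3 stands at the low end of this small set, level with compound 2 within the scatter and clearly under compound 1. The two steps that show this are a 1.5-fold lower number from compound 2 to compound 3 (0.17 log units; within the scatter) and a 2.9-fold lower number from compound 1 to compound 3 (0.46 log units; beyond the scatter). Compound 4 `CCCCCCCCCCCC(=O)NCC(C)(C)CC1=C(O)C(=O)c2ccccc2C1=O` differs from it in the chain: propyl in place of hydrogen on a saturated chain carbon, eight bonds along the chain from a carbonyl carbon. The closest earlier change is the added ethyl in a 1.5-fold lower number from compound 2 to compound 3 (0.17 log units; within the scatter), which is small. The new addition is only slightly larger, so a small further fall in this assay seems likely, probably within the scatter. The expected step is a 1.7-fold lower number from compound 3 to compound 4 (0.22 log units; within the scatter). Compound 4 is estimated at 10000 nM, with an expected range of 4500 nM to 22000 nM.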

Compound 4, half-maximal inhibitory concentration: 13900 nM
Compound 4: middle estimate off by 1.4-fold (0.14 log units), on the low side, and the stated range covers the measured number.
By their numbers in this assay, from the lowest: compounds 4, 3, 2 and 1 (each within the scatter of the next, the first and the last beyond it).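

In this assay the propyl addition gives a 1.2-fold lower number from compound 3 to compound 4 (0.08 log units; within the scatter) and, counted from the shorter chain, the pentyl addition gives a 1.8-fold lower number from compound 2 to compound 4 (0.25 log units; within the scatter); both steps lie within the scatter. Compound 2, compound 3 and compound 4 therefore cannot be told apart, so adding carbons at these places on the straight chain shows no measurable effect on this read-out. Nothing available here explains this flat stretch. Still open, going by these compounds, is whether a longer chain would stay level with these compounds, and what an amine or a carboxylic acid on the chain would do.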